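The compounds below may be only part of what the source reports. "The series", "measured", "known", "first", "only" and "open" are said of these compounds alone.

Three compounds share one core and differ only in the aryl group on the amine nitrogen. Compound 1 `CC1CC/C(=N\Nc2ccccc2F)c2ncc(C(=O)O)c(=O)n21` carries a 2-fluorophenyl there, and in a functional assay on the whole organism for inhibition, with Rattus norvegicus as the target (a higher number here means that more compound is needed for the effect, a lower number that less compound is needed), compound 1 gives 5 umol/kg. Compound 2 `CC1CC/C(=N\Nc2ccc(Br)cc2)c2ncc(C(=O)O)c(=O)n21` carries a 4-bromophenyl, and in this assay compound 2 gives 0.8 umol/kg, the second highest of the three numbers. Compound 3 `Cc1cccc(N/N=C2\CCC(C)n3c2ncc(C(=O)O)c3=O)c1` carries a 3-methylphenyl, and in this assay compound 3 gives 0.4 umol/kg. Among the measured steps, a 6.3-fold lower number from compound 1 to compound 2 (0.80 log units; beyond the scatter) and a 13-fold lower number from compound 1 to compound 3 (1.10 log units; beyond the scatter), whereas a 2.0-fold lower number from compound 2 to compound 3 (0.30 log units; within the scatter).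

Compound 4 `CC1CC/C(=N\Nc2ccc(C(=O)O)cc2)c2ncc(C(=O)O)c(=O)n21` is compound 2 with a single change: carboxy in place of bromo on an aromatic carbon. Going by the values given here, no measured compound carries a carboxy on this aryl ring, so the bearing steps are those from compound 1 to compound 2 and from compound 2 to compound 3, which show that swapping the aryl substituent moves this assay by modest to large amounts. With no guide on the carboxy itself, a small rise in the number is expected, a 1.9-fold higher number from compound 2 to compound 4 (0.27 log units; within the scatter). Compound 4 is therefore expected to give about 1.5 umol/kg in this assay, within a range of 0.4 umol/kg to 6 umol/kg.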

Compound 4, dose for 50% inhibition: 7.6 umol/kg
Beside the measured number, compound 4's estimate is 5.1-fold (0.70 log units) below it, outside the stated range (above it).
By their numbers in this assay, from the lowest: compounds 3 and 2 (each within the scatter of the next); then compounds 1 and 4 (each within the scatter of the next).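

In this assay, carboxy in place of bromo on an aromatic carbon, para to a large group, gives a 9.5-fold higher number from compound 2 to compound 4 (0.98 log units; beyond the scatter). The earlier compounds shown here showed only that the aryl substituent matters; this step shows that one carbon of the ring does not take every group alike, since the number goes up when a group with a hydrogen-bond donor and a hydrogen-bond acceptor replaces bromo, which has neither. Nothing available explains this rise.

As far as these compounds go, it remains open whether the carboxy as such drives the step, or whether a methyl ester, an amide or an amine on the same carbon would move the number as far. From the compounds shown here alone, it is equally open how a carboxy would behave on another carbon of this ring.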